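Replacing the 8-hydroxyquinolin-2-yl group of compound 2

The compounds below may be only part of what the source reports. "The series", "measured", "known", "first", "only" and "open" are said of these compounds alone.

In a functional assay on K562 cells (Homo sapiens) for inhibition, read by trypan blue exclusion, with a stated time of 72 h (a lower number here means a stronger inhibitor, a higher number a weaker inhibitor), compound 1 (`Cn1c(=O)c(S(=O)(=O)c2ccc(F)cc2F)cc2cnc(Nc3cccc4[nH]ccc34)nc21`) gives 1500 nM, and compound 2 (`Cn1c(=O)c(S(=O)(=O)c2ccc(F)cc2F)cc2cnc(Nc3ccc4cccc(O)c4n3)nc21`) gives 5000 nM, the higher of the two numbers. Compound 3 (`Cn1c(=O)c(S(=O)(=O)c2ccc(F)cc2F)cc2cnc(Nc3ccc4c(c3)C(=O)C(=O)N4)nc21`) carries a new group at the same place on the shared core: a group of 11 heavy atoms (8 carbon, 1 nitrogen, 2 oxygen; one five-membered non-aromatic ring with 1 hetero atom, one six-membered aromatic ring of carbon only) in place of a group of 11 heavy atoms (9 carbon, 1 nitrogen, 1 oxygen; one six-membered aromatic ring of carbon only, one six-membered aromatic ring with 1 hetero atom), on a nitrogen on an aromatic ring. Going by the values given here, the only measured step at this place, a 3.3-fold higher number from compound 1 to compound 2 (0.52 log units; beyond the scatter), is modest and does not show which way the new group should move the number, so no change beyond the scatter is expected in this assay. The expected step is a 1.7-fold lower number from compound 2 to compound 3 (0.22 log units; within the scatter). For compound 3 the estimated value is 3000 nM, with an expected range of 800 nM to 10000 nM.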

Compound 3, half-maximal inhibitory concentration: 30000 nM
The estimate for compound 3 lay 10-fold (1.00 log units) below the measured number, outside the stated range (above it).
By their numbers in this assay, from the lowest: compound 1; then compound 2; then compound 3.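

In this assay the place on a nitrogen on an aromatic ring shows a wider spread than before, with a 6.0-fold higher number from compound 2 to compound 3 (0.78 log units; beyond the scatter) and a 20-fold higher number from compound 1 to compound 3 (1.30 log units; beyond the scatter). The 8-hydroxyquinolin-2-yl group and the entering group both hold 11 heavy atoms, yet their numbers differ beyond the scatter, so heavy-atom count alone does not set the number here. Nothing at hand accounts for this order. From the compounds shown here alone, it remains open whether an amine or a carboxylic acid on the 1H-indol-4-yl group of compound 1 would move the number in either direction.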